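Replacing the group on the carbonyl carbon of compound 2

The compounds below may be only part of what the source reports. "The series", "measured", "known", "first", "only" and "open" are said of these compounds alone.

Measured so far in a physicochemical assay for solubility; on this read-out higher numbers stand for higher solubility and lower numbers for lower solubility:
- compound 1 `O=C(O)c1cccc(S(=O)(=O)N2CCC(NS(=O)(=O)c3cc(S(=O)(=O)c4ccccc4)ccc3C(F)(F)F)CC2)c1` gives 12500 nM
- compound 2 `CC(C)(C)OC(=O)N1CCC[C@@H]1C(=O)N1CCC(NS(=O)(=O)c2cc(S(=O)(=O)c3ccccc3)ccc2C(F)(F)F)CC1` gives 25000 nM

Compound 2, at 25000 nM, lies within the usual scatter of compound 1, at 12500 nM, so the two cannot be told apart. Compound 3 `O=C(C1CCNCC1)N1CCC(NS(=O)(=O)c2cc(S(=O)(=O)c3ccccc3)ccc2C(F)(F)F)CC1` awaits measurement. It carries piperidin-4-yl in place of 1-(tert-butoxycarbonyl)pyrrolidin-2-yl on a carbonyl carbon. Within the data shown here, no measured pair shows a comparable step, so the expectation is loose: a modest rise in this assay, not clearly beyond the scatter. The expected change is a 1.6-fold higher number from compound 2 to compound 3 (0.20 log units; within the scatter). For compound 3 the estimated value is 40000 nM, with an expected range from 16000 nM to 100000 nM.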

Compound 3, solubility: 100000 nM
The estimate for compound 3 lay 2.5-fold (0.40 log units) below the measured number; the measured number falls inside the stated range.
By their numbers in this assay, from the lowest: compounds 1 and 2 (each within the scatter of the next); then compound 3.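

In this assay, the group on the carbonyl carbon now separates two compounds: piperidin-4-yl in place of 1-(tert-butoxycarbonyl)pyrrolidin-2-yl gives a 4.0-fold higher number from compound 2 to compound 3 (0.60 log units; beyond the scatter), a step beyond the scatter. Compound 1 and compound 2 could not be told apart, yet (piperidin-4-yl)carbonyl in place of (3-carboxyphenyl)sulfonyl on the amine nitrogen in a ring gives an 8.0-fold higher number from compound 1 to compound 3 (0.90 log units; beyond the scatter), also beyond the scatter. No supporting measurement accounts for either step. Still open, on these data alone, is whether the ring or the tert-butoxycarbonyl group carries the step; pyrrolidin-2-yl without tert-butoxycarbonyl on the same carbonyl carbon would separate them.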